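The compounds below may be only part of what the source reports. "The series", "measured", "known", "first", "only" and "open" are said of these compounds alone.

In a functional assay on cells (Homo sapiens) for antiproliferative activity, read by MTT assay, with a stated time of 48 h (on this read-out lower numbers stand for stronger inhibition and higher numbers for weaker inhibition), compound 1 `CCN(CC)CCn1c(N)c(-c2nc3ccccc3[nH]2)c2nc(C#N)c(C#N)nc21` gives 25400 nM. Compound 2 `N#Cc1nc2c(-c3nc4ccccc4[nH]3)c(N)n(CCO)c2nc1C#N` reads > 50000 nM, which is a limit of the assay and not a number. Compound 3 `CCN(CC)CCCn1c(N)c(-c2nc3ccccc3[nH]2)c2nc(C#N)c(C#N)nc21` gives 28900 nM, level with compound 1 within the scatter. Compound 4 `CN1CCN(CCCn2c(N)c(-c3nc4ccccc4[nH]3)c3nc(C#N)c(C#N)nc32)CC1` carries 3-(4-methylpiperazin-1-yl)propyl in place of 3-(diethylamino)propyl: 4-methylpiperazin-1-yl in place of diethylamino on a saturated chain carbon, three bonds along the chain from an aromatic nitrogen. Among the compounds with values here, no measured step makes this exchange. The closest guides are a 1.1-fold higher number from compound 1 to compound 3 (0.06 log units; within the scatter) and an at least 1.9-fold higher number from compound 1 to compound 2 (0.29 log units; that floor lies within the scatter), and neither shows a change beyond the scatter. No step beyond the scatter is therefore expected in this assay. The expected step is a 1.2-fold lower number from compound 3 to compound 4 (0.06 log units; within the scatter). Compound 4 is estimated at 25000 nM, with an expected range from 10000 nM to 50000 nM.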

Compound 4, half-maximal inhibitory concentration: 4520 nM
The estimate for compound 4 lay 5.5-fold (0.74 log units) above the measured number; the whole stated range lies above it.
By their numbers in this assay, from the lowest: compound 4; then compounds 1 and 3 (each within the scatter of the next). At a limit, above all of these: compound 2.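

In this assay, within the data shown here, no earlier step at this chain end went beyond the scatter, whereas 4-methylpiperazin-1-yl in place of diethylamino on the propyl chain gives a 6.4-fold lower number from compound 3 to compound 4 (0.81 log units; beyond the scatter). The piperazine compound also stands apart from the shorter chains, with a 5.6-fold lower number from compound 1 to compound 4 (0.75 log units; beyond the scatter) and an at least 11-fold lower number from compound 2 to compound 4 (1.04 log units; beyond the scatter). The second of these steps starts from a limit and not a number: the limit of > 50000 nM in this assay, at which 1 of the 4 values shown sits.

From the compounds shown here alone, whether the ring or its second nitrogen carries the change stays open, and piperidin-1-yl or morpholin-4-yl on the same chain would separate the two. The 2-(4-methylpiperazin-1-yl)ethyl chain would show whether chain length matters with this ring.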